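Removing the Bromo Group of Compound 2

The source may hold more compounds than are shown below. What is called first, only, known or untested is meant among the compounds shown, and "the series" means these compounds.

Compound 1 `C=C1C(=O)N(c2ccccc2)N(c2ccccc2)C1c1ccccc1` gives 3820 nM in a functional assay on NALM-6 cells (Homo sapiens) for inhibition, read by MTT assay, with a stated time of 48 h; on this read-out higher numbers stand for weaker inhibition and lower numbers for stronger inhibition. Compound 2 `C=C1CN(C)N(c2ccc(Br)cc2)C1=O` gives 62000 nM in this assay. Compound 3 `C=C1C(=O)N(c2ccccc2)N(C)C1c1ccc(OC)cc1` gives 49300 nM in this assay.

Among these three, compound 2 carries the highest number; compound 3 lies within the scatter of it, while compound 1 stands well below, beyond the scatter. Compound 4 `C=C1CN(C)N(c2ccccc2)C1=O` has not been measured. It differs from compound 2 by one change: hydrogen in place of bromo on an aromatic carbon. Among the compounds with values here, no pair of measured compounds shows this change, so the expectation rests on compound 2 alone. The step from compound 2 to compound 4 is expected to be small, most likely none beyond the scatter, as a 1.1-fold lower number from compound 2 to compound 4 (0.05 log units; within the scatter). Compound 4 is therefore estimated at 55000 nM, within 15000 nM to 200000 nM.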

Compound 4, half-maximal inhibitory concentration: 56000 nM
The estimate for compound 4 lay 1.0-fold (0.01 log units) below the measured number; measured number inside the range.
By their numbers in this assay, from the lowest: compound 1; then compounds 3, 4 and 2 (each within the scatter of the next).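

In this assay, within the data shown here, hydrogen in place of bromo on an aromatic carbon gives a 1.1-fold lower number from compound 2 to compound 4 (0.04 log units; within the scatter), the first step here that isolates a single change. At this position, para to a group of 8 heavy atoms, the bromo group can therefore leave without a shift beyond the scatter. No measurement shown here accounts for this result.

As far as these compounds go, whether an amine or a carboxylic acid at this position would shift the number remains open. So does whether the same change would be equally small on the core of compound 1.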